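A Methanesulfonamidophenyl Variant of the Shared Core

The compounds below may be only part of what the source reports. "The series", "measured", "known", "first", "only" and "open" are said of these compounds alone.

Three measured compounds share one core. Compound 1 `O=C(O)Cc1sc(C(c2ccc(F)cc2)c2ccc(F)cc2)nc1-c1cc(F)cc(F)c1` gives 35 nM in an in vitro assay on HEK385-7 cells for displacement of a labelled ligand from prostaglandin D2 receptor 2 (Homo sapiens); a lower number here means a stronger inhibitor, a higher number a weaker inhibitor. Compound 2 `O=C(O)Cc1sc(C(c2ccc(F)cc2)c2ccc(F)cc2)nc1-c1ccnc(N2CCC2)c1` gives 660 nM in this assay, and compound 3 `Cc1cc(-c2nc(C(c3ccc(F)cc3)c3ccc(F)cc3)sc2CC(=O)O)cnc1N` gives 880 nM. Compound 3 stands at the highest of the three numbers; its step from compound 2, a 1.3-fold higher number from compound 2 to compound 3 (0.12 log units; within the scatter), is within the scatter, while the step of a 25-fold higher number from compound 1 to compound 3 (1.40 log units; beyond the scatter) is large. Compound 4 `CS(=O)(=O)Nc1cccc(-c2nc(C(c3ccc(F)cc3)c3ccc(F)cc3)sc2CC(=O)O)c1` differs from compound 3 in one place: 3-(methanesulfonamido)phenyl in place of 6-amino-5-methylpyridin-3-yl on an aromatic carbon.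

Among the compounds with values here, two measured steps bear on this change. Both a 19-fold higher number from compound 1 to compound 2 (1.28 log units; beyond the scatter) and a 25-fold higher number from compound 1 to compound 3 (1.40 log units; beyond the scatter) show that exchanging the six-membered aromatic ring of carbon only for a ring with one hetero atom raised the number strongly. Within the data shown here, compound 4 returns to a ring of carbon only, but carries a methanesulfonamido group that no measured compound has, so the size of the return is uncertain. For compound 4 a downward step beyond the scatter is expected, a 5.9-fold lower number from compound 3 to compound 4 (0.77 log units; beyond the scatter). Compound 4 is estimated at 150 nM, within a range from 40 nM to 600 nM.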

Compound 4, half-maximal inhibitory concentration: 40 nM
Beside the measured number, compound 4's estimate is 3.8-fold (0.57 log units) above it; the measured number falls inside the stated range.
By their numbers in this assay, from the lowest: compounds 1 and 4 (each within the scatter of the next); then compounds 2 and 3 (each within the scatter of the next).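

At this place on the five-membered aromatic ring, next to the ring nitrogen, 3-(methanesulfonamido)phenyl removes the whole loss that came with the two pyridinyl groups in this assay: a 22-fold lower number from compound 3 to compound 4 (1.34 log units; beyond the scatter) and a 17-fold lower number from compound 2 to compound 4 (1.22 log units; beyond the scatter). The same group stands level with 3,5-difluorophenyl, a 1.1-fold higher number from compound 1 to compound 4 (0.06 log units; within the scatter), so this position accepts a substituted ring of carbon only with either of two quite different sets of substituents, and among these four compounds, none goes against the split between rings of carbon only and rings with a hetero atom. Nothing available here points to a cause for these steps.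

The ring nitrogen and the groups on the ring change together in these compounds, so their shares in the higher numbers of compound 2 and compound 3 remain unseparated. Going by these compounds, what a methanesulfonamido group would give on a pyridine ring, or a plain amine on the phenyl ring, stays open.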